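From a Methoxycarbonyl Aryl to a Dimethyl Aryl

This account rests on a few compounds, and the source may have more. Where it says the series, first, only, none or still open, it means among the compounds named here.

The set holds three measured compounds and one awaiting measurement. Compound 1 `COc1ccc(C2=C(c3cc(OC)c(OC)c(OC)c3)C(=O)C(O[SiH2]C(C)(C)C)C2)cc1OC(C)C` gives 7.1 ug/mL in an ADME assay on PA-1 cells (Homo sapiens) for cytotoxicity, read by MTT assay, with a stated time of 72 h; a higher number here means a weaker inhibitor, a lower number a stronger inhibitor. Compound 2 `COC(=O)c1cc(C2=C(c3cc(OC)c(OC)c(OC)c3)C(=O)CC2O[SiH2]C(C)(C)C)ccc1OC` reaches only a limit in this assay, giving > 100 ug/mL, which is a limit and not a number. Compound 3 `CC(=O)OC1C/C(=N/O)C(c2ccccc2)=C1c1ccccc1` likewise yields only a limit in this assay, > 100 ug/mL. Compound 2 therefore sits at the limit of > 100 ug/mL in this assay, at which 2 of the 3 values shown sit, the weak end of the numbers shown. Compound 1 alone carries a measured number.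

Compound 4 `COc1cc(C2=C(c3cc(C)c(OC)c(C)c3)C(O[SiH2]C(C)(C)C)CC2=O)cc(OC)c1OC` has not yet been measured in this assay. It differs from compound 2 in one place: 4-methoxy-3,5-dimethylphenyl in place of 4-methoxy-3-(methoxycarbonyl)phenyl on a double-bonded ring carbon. For the measured compounds named here, no step between measured compounds is available to size this change, and compound 2 itself offers only a limit as the starting point. A step toward a lower number, beyond the usual scatter, is expected, expressed as an at least 5.0-fold lower number from compound 2 to compound 4 (0.69 log units; beyond the scatter). Compound 4 is estimated at 20 ug/mL in this assay, with a range from 3 ug/mL to 100 ug/mL.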

Compound 4, half-maximal inhibitory concentration: 32 ug/mL
Compound 4: the middle estimate sits 1.6-fold (0.20 log units) below what was measured; the range from low to high includes it.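

In this assay compound 2 gives > 100 ug/mL which is a limit and not a number. For the compounds shown here, putting 4-methoxy-3,5-dimethylphenyl in place of 4-methoxy-3-(methoxycarbonyl)phenyl on a double-bonded ring carbon gives an at least 3.1-fold lower number from compound 2 to compound 4 (0.49 log units; beyond the scatter) and so shows for the first time that the group at this place can bring the read-out from a limit to a measured number. The size of this step can be stated only as a minimum because compound 2 stands at a limit: the limit of > 100 ug/mL in this assay, at which 2 of the 4 values shown sit.

The compounds shown leave open whether the loss of the methoxycarbonyl or the arrival of the methyl groups carries the step, as the two come together in this one change. They also leave open how a carboxylic acid, an amine or an ethyl group on that phenyl ring would read in this assay.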